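Cyclopentyl for Isopentyl on the Acyl Carbonyl

This account rests on a few compounds, and the source may have more. Where it says the series, first, only, none or still open, it means among the compounds named here.

Measured compounds:
compound 1, `CC(C)CCC(=O)N[C@@H](C(=O)N1CCC(c2ccc(Cl)cc2)CC1)C(C)C`: 26 nM
compound 2, `CC(C)C(NC(=O)c1ccccc1)C(=O)N1CCN(c2ccc(Cl)cc2)CC1`: 525 nM
compound 3, `CCCC(NC(=O)c1ccccc1C)C(=O)N1CCC(c2ccc(Cl)cc2)CC1`: 152 nM

In an assay on THP-1 cells for displacement of a labelled ligand from C-C chemokine receptor type 1 (Homo sapiens) (on this read-out higher numbers stand for weaker inhibition and lower numbers for stronger inhibition), compound 1 gives 26 nM, the lowest of the three values. Compound 3 stands closest with 152 nM and compound 2 furthest with 525 nM; both gaps to compound 1 lie beyond the scatter, so compound 1 is the strongest inhibitor shown.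

Compound 4, `CC(C)[C@@H](NC(=O)C1CCCC1)C(=O)N1CCC(c2ccc(Cl)cc2)CC1`, has not yet been measured. It differs from compound 1 in one place: cyclopentyl in place of isopentyl on a carbonyl carbon. For the measured compounds named here, the new group keeps the same count of heavy atoms on the carbonyl carbon whose other neighbour is the amide-type nitrogen, and no comparable step is available among the measured compounds.

In this assay compound 4 is expected to stay close to compound 1, with a step of a 1.2-fold higher number from compound 1 to compound 4 (0.09 log units; within the scatter) not beyond the scatter. Compound 4 is therefore estimated at 32 nM, between 10 nM and 100 nM.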

Compound 4, half-maximal inhibitory concentration: 70 nM
Compound 4: middle estimate off by 2.2-fold (0.34 log units), on the low side; the range from low to high includes it.
By their numbers in this assay, from the lowest: compound 1; then compound 4; then compound 3; then compound 2.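

Swapping isopentyl for cyclopentyl on the carbonyl carbon gives a 2.7-fold higher number from compound 1 to compound 4 (0.43 log units; beyond the scatter) in this assay, a modest step and the first comparison at this position that changes only one place. The count of heavy atoms stays the same, so the read-out at this position depends on more than that count: the open chain and the ring are distinguished. Nothing available accounts for this difference.

On these data alone, it remains open how a cyclobutyl or cyclohexyl ring on this carbonyl carbon would compare with compound 4. A longer chain or an ether oxygen in the chain of compound 1 also remains untested in the compounds shown.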